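This account rests on a few compounds, and the source may have more. Where it says the series, first, only, none or still open, it means among the compounds named here.

Of the compounds shown here, three that share a core have been tested so far. Among the measured compounds shown here, in a functional assay on A549 cells (Homo sapiens) for antiproliferative activity, read by WST assay, with a stated time of 72 h (a higher number here means that more compound is needed for the effect, a lower number that less compound is needed), compound 1 `CCCCNCC(=O)Nc1ccc(/C(N)=N/O)cc1` gives 395000 nM, the only true number in the set. Compound 2 `CCCCCCNC(=O)Nc1ccc(/C(N)=N/O)cc1` gives > 1000000 nM, which is a limit of the assay and not a number. Compound 3 `CCCCCCNCCCCC(=O)Nc1ccc(/C(N)=N/O)cc1` gives > 1000000 nM, which is also a limit. From the compounds shown here alone, compound 2 therefore stands at the limit of > 1000000 nM in this assay, at which 2 of the 3 values shown sit, so its real value is unknown and any step away from it can only be sized loosely.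

The next compound to be tested is compound 4 `CCCCNC(=O)Nc1ccc(/C(N)=N/O)cc1`. It differs from compound 2 in one place: hydrogen in place of ethyl on a saturated chain carbon, four bonds along the chain from an amide-type nitrogen. In words, this is hydrogen in place of ethyl on a saturated chain carbon, four bonds along the chain from an amide-type nitrogen.

For the measured compounds named here, no measured pair in the set shows what a change of this kind does in this assay. The expectation is therefore modest: a small step towards lower numbers, or none beyond the scatter. Going by the values given here, the one number from compound 1, at 395000 nM, suggests that values in this set can fall within measurable reach, though only just. Compound 4 could still be reported only as a limit. The expected change is an at least 1.2-fold lower number from compound 2 to compound 4 (0.09 log units; that floor lies within the scatter). For compound 4 the estimated value is 800000 nM, with an expected range from 300000 nM to 1000000 nM.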

Compound 4, half-maximal effective concentration: > 1000000 nM
Compound 4: only a limit was reported (the forecaster's own chance of this, stated with the estimate: 50%); middle value at least 1.2-fold (0.09 log units) from the limit.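

Compound 4 is also reported only as a limit, > 1000000 nM, in this assay, so replacing ethyl with hydrogen on a saturated chain carbon, four bonds along the chain from an amide-type nitrogen, leaves a step from compound 2 that cannot be read. Among the compounds shown here, compound 4 does allow a first readable comparison in the set, at a different place: with butylamino in place of (butylamino)methyl on a carbonyl carbon, the data show an at least 2.5-fold higher number from compound 1 to compound 4 (0.40 log units; beyond the scatter). The change on the carbonyl carbon is therefore the first one shown to move the number, while the change on the saturated chain carbon shows no movement that can be measured.

The true size of any effect of the ethyl-to-hydrogen change remains open, with most of the set reported at the same limit: the limit of > 1000000 nM in this assay, at which 3 of the 4 values shown sit.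

Also open, from the compounds shown here alone, is whether a carboxylic acid or a hydroxyl group in place of ethyl on this same chain carbon would bring a compound within measurable reach.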